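Adding a dimethylaminopropyl chain to a seven-membered core

A few compounds are considered here, and "the series" means these few. Any claim that something is new, unique, unknown or untested is made for them only; others in the source may bear on it.

Of the compounds shown here, two have been measured in a functional assay on the whole organism for positive allosteric modulation, with Rattus norvegicus as the target; a lower number here means that less compound is needed, a higher number that more compound is needed for the effect. Compound 2, with the structure `CCc1nn(C)c2c1C(c1cccc(F)c1)=NCCN2`, is the only one of them to give a number: in this assay compound 2 gives 2.5 mg/kg. Compound 1, with the structure `Cc1nn(C)c2c1C(c1cccc(F)c1)=NCCN2CCCN(C)C`, does not give a number at all; in this assay compound 1 reaches only a limit of the assay, > 10 mg/kg, and so (the limit of > 10 mg/kg in this assay, at which 1 of the 2 values shown sits).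

The step of interest leads from compound 2 to compound 3, whose structure is `CCc1nn(C)c2c1C(c1cccc(F)c1)=NCCN2CCCN(C)C`. The change is 3-(dimethylamino)propyl in place of hydrogen on a nitrogen on an aromatic ring in a ring. Within the data shown here, no pair of measured compounds differing in one place is at hand, so the size of this step cannot be read from the data.

The expectation is nevertheless that compound 3 needs more compound than compound 2, with a step of a 4.0-fold higher number from compound 2 to compound 3 (0.60 log units; beyond the scatter) that goes beyond the usual scatter, because compound 1 gives only the limit > 10 mg/kg. Compound 3 is therefore estimated at 10 mg/kg in this assay, within a range from 3 mg/kg to 30 mg/kg, and a limit rather than a number is thought likely.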

Compound 3, minimum effective dose: > 10 mg/kg
Compound 3 gave a limit, no number; the forecaster's own chance of this, stated with the estimate: 60%; the middle value lies on the limit itself.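

Compound 2 and compound 3 differ in one place only, so the effect of 3-(dimethylamino)propyl in place of hydrogen on this nitrogen can now be read on its own, as an at least 4.0-fold higher number from compound 2 to compound 3 (0.60 log units; beyond the scatter) in this assay. From the compounds shown here alone, compound 3 ends at a limit of the assay, which makes this step a minimum: more compound is needed with the chain than without it, but the true size of the change remains unknown. Both compounds carrying the chain end at the same limit, so the step between them, methyl in place of hydrogen on a saturated chain carbon bound to an aromatic carbon, cannot be read: the limit of > 10 mg/kg in this assay, at which 2 of the 3 values shown sit.

Going by these compounds, it remains open whether the higher dose goes with the length of the chain or with its dimethylamino end, a question that a plain propyl group or a 2-(dimethylamino)ethyl group on the same nitrogen would help to settle. Also open, on these data alone, is how a small group such as acetyl on this nitrogen would compare with the hydrogen of compound 2.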